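One More Methoxy Group: Predicting Compound 4

The source may hold more compounds than are shown below. What is called first, only, known or untested is meant among the compounds shown, and "the series" means these compounds.

Compound 1 `O=S(=O)(c1ccccc1)c1nc2ccccc2nc1Nc1ccccc1` and compound 2 `COc1ccc(Nc2nc3ccccc3nc2S(=O)(=O)c2ccccc2)cc1` differ by methoxy in place of hydrogen on an aromatic carbon. In a functional assay on A549 cells (Homo sapiens) for cytotoxicity, read by MTT assay, with a stated time of 72 h (a higher number here means a weaker inhibitor, a lower number a stronger inhibitor), compound 1 gives 26300 nM, and compound 2 gives 11900 nM; this amounts to a 2.2-fold lower number from compound 1 to compound 2 (0.34 log units; beyond the scatter). Compound 3 `COc1ccc(S(=O)(=O)c2nc3ccccc3nc2Nc2cc(OC)cc(OC)c2)cc1` belongs to the same series, but the difference between its core and that of compound 1 is not broken down here. In this assay compound 3 gives 12700 nM, close to compound 2. Compound 4 `COc1ccc(S(=O)(=O)c2nc3ccccc3nc2Nc2cc(OC)c(OC)c(OC)c2)cc1` has not yet been measured; it differs from compound 3 by methoxy in place of hydrogen on an aromatic carbon. This is the same kind of change as from compound 1 to compound 2, yet not the same: in compound 4 the new group sits ortho to two methoxy groups as well as para to a large group, whereas in compound 2 it sits only para to a large group. Because the earlier change gave a 2.2-fold lower number from compound 1 to compound 2 (0.34 log units; beyond the scatter), a lower number is expected for compound 4 as well, though a more cautious step is expected given the different setting, namely a 1.5-fold lower number from compound 3 to compound 4 (0.17 log units; within the scatter). Compound 4 is therefore estimated at 8500 nM in this assay, with a plausible range from 3000 nM to 25000 nM.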

Compound 4, half-maximal inhibitory concentration: 5170 nM
Compound 4: middle estimate off by 1.6-fold (0.22 log units), on the high side, within the range that was stated.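

Methoxy in place of hydrogen on an aromatic carbon again gave a lower number in this assay, with a 2.5-fold lower number from compound 3 to compound 4 (0.39 log units; beyond the scatter). Set beside the earlier step, the change carried over to the second core with no difference in size that can be told apart: the same change on two cores in this assay, a 2.2-fold lower number (0.34 log units; beyond the scatter) from compound 1 to compound 2 and a 2.5-fold lower number (0.39 log units; beyond the scatter) from compound 3 to compound 4, 1.1-fold (0.05 log units) apart, within the scatter of two such steps. Within the data shown here, this rests on only two pairs and does not show that the step would hold on other cores. The data do not tell what lies behind the step.

The compounds shown leave open whether a hydroxyl group, an amine or a longer chain such as ethoxy in place of the methoxy would give a step of similar size. They also leave open whether the step would appear in cells other than those of this assay.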